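The source may report more compounds than this note shows. Statements on the series, on what has been measured and on what is new or still open speak of the compounds shown alone.

The three measured compounds share one core and differ only in the alkyl groups attached to it. In a functional assay on LS174T cells (Homo sapiens) for inhibition, read by MTT assay, with a stated time of 72 h (on this read-out higher numbers stand for weaker inhibition and lower numbers for stronger inhibition), compound 1 `CC(C)c1ccc(C(=O)/C=C/C(=O)O)c(C(C)C)c1` gives 5360 nM, compound 2 `CC(C)(C)c1ccc(C(=O)/C=C/C(=O)O)cc1` gives 8740 nM, and compound 3 `CCc1c(C(=O)/C=C/C(=O)O)cc(C(C)C)cc1C(C)C` gives 12400 nM. Compound 2 holds the second highest of the three numbers, yet both of the others lie within the usual scatter of it, so no order among them can be read. Compound 4 `CCCCc1ccc(C(=O)/C=C/C(=O)O)cc1` differs from compound 2 by butyl in place of tert-butyl on an aromatic carbon. Within the data shown here, no measured pair shows a change of this kind, so in this assay no step beyond the scatter is expected in either direction. Compound 4 is therefore estimated at 8000 nM, within the range 3500 nM to 18000 nM. This estimate means a step of a 1.1-fold lower number from compound 2 to compound 4 (0.04 log units; within the scatter) that stays inside the scatter.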

Compound 4, half-maximal inhibitory concentration: 6740 nM
For compound 4 the middle estimate is 1.2-fold (0.07 log units) above the measured one, and the stated range covers the measured number.
By their numbers in this assay, from the lowest: compounds 1, 4, 2 and 3 (each within the scatter of the next, the first and the last beyond it).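

In this assay, among these compounds, the step of a 1.3-fold lower number from compound 2 to compound 4 (0.11 log units; within the scatter) is the first direct comparison at this position, and it lies within the scatter. Tert-butyl and butyl, each with 4 heavy atoms, therefore cannot be told apart here, so rearranging these carbons on the aromatic carbon produces no readable change. Nothing available offers a reason for this result. The compounds shown leave open whether an amine, a carboxylic acid or a longer chain such as octyl at this position would move the number beyond the scatter.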